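The compounds below may be only part of what the source reports. "The series", "measured", "known", "first", "only" and "open" are said of these compounds alone.

Measured in an ADME assay on RAW264.7 cells (Mus musculus) for cytotoxicity, read by MTT assay, with a stated time of 24 h, in the absence of a further agent; on this read-out lower numbers stand for stronger inhibition and higher numbers for weaker inhibition:

Compound 1 `CCOCCOc1ccc(C(O)C2OC(=O)c3c(OC)cc(OC)cc32)cc1`: > 40000 nM
Compound 2 `C=CCCOc1ccc(C(O)C2OC(=O)c3c(OC)cc(OC)cc32)cc1`: > 40000 nM
Compound 3 `COc1cc(OC)c2c(c1)C(C(O)c1ccc(OCc3ccc(Cl)cc3)cc1)OC2=O`: > 40000 nM

Each of these entries is a limit of this assay and not a number. Compound 3 therefore has no exact place on the scale: compound 3 gives > 40000 nM, which is a limit. Overall, the data show (the limit of > 40000 nM in this assay, at which 3 of the 3 values shown sit).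

Compound 4 `COc1cc(OC)c2c(c1)C(C(O)c1ccc(OCC3CCCCC3)cc1)OC2=O` has not yet been measured. Its difference from compound 3 is cyclohexyl in place of 4-chlorophenyl on a saturated chain carbon bound to an oxygen on an aromatic ring: cyclohexyl in place of 4-chlorophenyl, on a saturated chain carbon bound to an oxygen on an aromatic ring.

Two measured changes fall at that same place: a step that the two limits leave unreadable from compound 1 to compound 3 and a step that the two limits leave unreadable from compound 2 to compound 3. The third is a step that the two limits leave unreadable from compound 1 to compound 2. None has a readable size, so none shows a direction, and no step beyond the usual scatter is expected. The estimated change is a step that the limit leaves unreadable from compound 3 to compound 4.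

Compound 4 is expected to remain at the limit, with an estimated value of 50000 nM and an expected range from 20000 nM to 100000 nM.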

Compound 4, half-maximal inhibitory concentration: > 40000 nM
Compound 4: a limit, no number; the forecaster's own chance of this, stated with the estimate: 85%; the middle value is on the limit's open side.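

In this assay compound 4 gives > 40000 nM, which is a limit and not a number, so the steps to it from compound 1, compound 2 and compound 3 cannot be read. The compounds shown leave open whether any of these groups on the shared core changes cytotoxicity at all.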